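The source may hold more compounds than are shown below. What is called first, only, known or untested is meant among the compounds shown, and "the series" means these compounds.

Measured in an ADME assay on L132 cells (Homo sapiens) for cytotoxicity, read by MTT assay, with a stated time of 72 h; on this read-out higher numbers stand for weaker inhibition and lower numbers for stronger inhibition:
- compound 1 `COc1ccc(C2=C(c3cc(OC)c(OC)c(OC)c3)C(=O)C(O[SiH2]C(C)(C)C)C2)cc1`: 9 ug/mL
- compound 2 `COc1ccc(C2=C(c3cc(OC)c(OC)c(OC)c3)C(=O)CC2O)cc1O`: < 1 ug/mL
- compound 3 `COc1ccc(C2=C(c3cc(OC)c(OC)c(OC)c3)C(=O)C(OC(C)=O)C2)cc1Cl`: < 1 ug/mL

In this assay compound 2 reads < 1 ug/mL, which is a limit of the assay and not a number. Its true position is therefore unknown. Compound 3 also reads < 1 ug/mL, again a limit. The shared floor is the limit of < 1 ug/mL in this assay, at which 2 of the 3 values shown sit. Compound 1 is the only one of the three with a number, 9 ug/mL.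

The next compound is compound 4 `COc1ccc(C2=C(c3cc(OC)c(OC)c(OC)c3)C(=O)CC2O)cc1`, which has hydrogen in place of hydroxy on an aromatic carbon compared with compound 2. The change sits ortho to a methoxy group and meta to a large group, and reads 3-hydroxy-4-methoxyphenyl to 4-methoxyphenyl: hydrogen in place of hydroxy on an aromatic carbon. Within the data shown here, no measured pair isolates this change, so the expectation is tentative. A modest move towards weaker inhibition in this assay is expected, and the estimated size is an at least 1.5-fold higher number from compound 2 to compound 4 (0.17 log units; that floor lies within the scatter). A reading at the limit again would not be a surprise.

For compound 4 the expected value is estimated at 1.5 ug/mL, within an estimated range of 0.3 ug/mL to 8 ug/mL.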

Compound 4, half-maximal inhibitory concentration: 10 ug/mL
Compound 4: the middle estimate sits 6.7-fold (0.82 log units) below what was measured, outside the stated range (above it).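

Going from 3-hydroxy-4-methoxyphenyl to 4-methoxyphenyl gives the series its first comparison of compounds that differ in one place, and in this assay the step is an at least 10-fold higher number from compound 2 to compound 4 (1.00 log units; beyond the scatter). The aromatic hydroxy, ortho to the methoxy group, therefore matters at this position in this read-out, since with hydrogen in its place compound 4 gives a number, 10 ug/mL. The full size of the step stays unknown because the reading of compound 2 is a limit and not a number: the limit of < 1 ug/mL in this assay, at which 2 of the 4 values shown sit.

Compound 3 carries chlorine at this place but also differs from compound 2 on the other side of the core, so it does not show what chlorine alone does at this position. The reading of compound 3, < 1 ug/mL, is likewise a limit. Open questions are whether an amine or a methoxy group at this place would keep the reading at the floor, and how far compound 2 actually lies below the limit, which only a reading that resolves values under the floor could settle.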